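From 1,3-thiazol-5-yl to thiophen-3-yl on a carbonyl carbon

The source may hold more compounds than are shown below. What is called first, only, known or untested is meant among the compounds shown, and "the series" means these compounds.

In a functional assay on HT-29 cells (Homo sapiens) for inhibition, read by colorimetric assay and sulforhodamine B assay, with a stated time of 48 h (a lower number here means a stronger inhibitor of growth, a higher number a weaker inhibitor of growth), compound 1 (`CCCCCCCCCCCC[C@@H](O)[C@H]1CC[C@H]([C@H](O)CCCCCCCCCCNC(=O)c2cccs2)O1`), with thiophen-2-yl on a carbonyl carbon, gives 2190 nM as its value. Compound 2 (`CCCCCCCCCCCC[C@@H](O)[C@H]1CC[C@H]([C@H](O)CCCCCCCCCCNC(=O)c2ccco2)O1`) carries furan-2-yl there and gives 100000 nM in the same test, while compound 3 (`CCCCCCCCCCCC[C@@H](O)[C@H]1CC[C@H]([C@H](O)CCCCCCCCCCNC(=O)c2cncs2)O1`) carries 1,3-thiazol-5-yl and gives 100000 nM there. Compound 3 thus shares the highest of the three numbers with compound 2, with no change at the digits printed from compound 2 to compound 3 (within the scatter) separating them. Compound 4 (`CCCCCCCCCCCC[C@@H](O)[C@H]1CC[C@H]([C@H](O)CCCCCCCCCCNC(=O)c2ccsc2)O1`) differs from compound 3 in one place, with thiophen-3-yl in place of 1,3-thiazol-5-yl on a carbonyl carbon as the whole change. Going by the values given here, two measured steps bear on it: a 46-fold higher number from compound 1 to compound 2 (1.66 log units; beyond the scatter) and a 46-fold higher number from compound 1 to compound 3 (1.66 log units; beyond the scatter) are both large, and both leave the thiophen-2-yl of compound 1. Among the compounds with values here, no measurement yet shows how thiophen-3-yl compares with thiophen-2-yl. A large step to a lower number is therefore expected in this assay, returning most of the way towards compound 1. For compound 4 the estimated value is 4000 nM, with an expected range from 1200 nM to 30000 nM as its span, which amounts to an expected 25-fold lower number from compound 3 to compound 4 (1.40 log units; beyond the scatter) overall.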

Compound 4, concentration for 50% growth inhibition: 1910 nM
Compound 4: the middle estimate sits 2.1-fold (0.32 log units) above what was measured; the measured number falls inside the stated range.
By their numbers in this assay, from the lowest: compounds 4 and 1 (each within the scatter of the next); then compounds 2 and 3 (each within the scatter of the next).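

In this assay the thiophen-3-yl group of compound 4 separates clearly from the other two rings, with a 52-fold lower number from compound 3 to compound 4 (1.72 log units; beyond the scatter) and a 52-fold lower number from compound 2 to compound 4 (1.72 log units; beyond the scatter), so the large loss seen earlier does not extend to every change away from thiophen-2-yl. With a 1.1-fold lower number from compound 1 to compound 4 (0.06 log units; within the scatter), thiophen-3-yl and thiophen-2-yl on this carbonyl carbon cannot be told apart here. Among the four compounds the two thiophene rings stand together, yet a sulfur atom in the ring is not enough, as compound 3 with its 1,3-thiazol-5-yl goes against that, and a single ring hetero atom is not enough either, as compound 2 shows.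

As far as these compounds go, whether a phenyl or a pyridin-3-yl ring on this carbonyl carbon would sit with the thiophenes or with compound 2 and compound 3 remains open. Nothing measured here gives a reason for this split between the rings.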